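This account rests on a few compounds, and the source may have more. Where it says the series, first, only, none or still open, it means among the compounds named here.

Series notes. Compound 1 `Cc1ccc(C2CNN=C2S(=O)(=O)CC2=NCCS2)cc1` gives 52.2% in a functional assay, read by Griess assay, with a stated time of 150 min, tested at 100 ug/mL; on this read-out lower numbers stand for a weaker effect and higher numbers for a stronger effect at the one concentration tested. For the measured compounds named here, compound 2 `Cc1ccc(C2CNN=C2S(=O)(=O)CC2=NCCO2)cc1` gives 51.4% and is separated from the only other measured compound by a number 0.8 percentage points lower from compound 1 to compound 2 (within the scatter), within the scatter. Compound 3 `O=S(=O)(CC1=NCCO1)C1=NNCC1c1ccc(Cl)cc1` differs from compound 2 by chloro in place of methyl on an aromatic carbon. Going by the values given here, no measured step touches this aromatic carbon; the single step on record, a number 0.8 percentage points lower from compound 1 to compound 2 (within the scatter), concerns the group on the chain carbon bound to the sulfonyl sulfur and was itself within the scatter. Nothing therefore points to a step beyond the scatter, and a number 0.4 percentage points lower from compound 2 to compound 3 (within the scatter) is expected to be small. Compound 3 is estimated at 51%, between 36% and 66%.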

Compound 3, a percentage reported as activity, at one concentration (the size of the read-out at that concentration, not a potency): "not active" (no number reported)
For compound 3 the study gives words and no number; there is nothing to compare the estimate with.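

For the compounds shown here, compound 3 carries only the words "not active" in this assay, so no step from compound 2 to compound 3 can be read. No supporting data bear on this result. The compounds shown leave open how far 4-methylphenyl to 4-chlorophenyl moves this read-out.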